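The source may hold more compounds than are shown below. What is called first, only, known or untested is meant among the compounds shown, and "the series" means these compounds.

Compound 1 `OC[C@H]1O[C@@H](n2cnc3c(NCc4ccc(Cl)cc4Cl)ncnc32)[C@H](O)[C@@H]1O` is tested in a functional assay on K562 cells (Homo sapiens) for antiproliferative activity, with a stated time of 72 h (a higher number here means a weaker inhibitor, a lower number a stronger inhibitor), where compound 1 gives 106000 nM, the highest of the two numbers shown. Compound 3 `COc1ccc(CNc2ncnc3c2ncn3C2OC(CO)[C@@H](O)[C@H]2O)c(O)c1` gives 80800 nM in this assay, which lies within the scatter of compound 1. Compound 2 `COc1cccc(CNc2ncnc3c2ncn3[C@@H]2O[C@H](CO)[C@@H](O)[C@H]2O)c1OC` reaches only a limit of the assay, > 166000 nM. Among the compounds with values here, the one measured step that bears on the change at hand is an at least 1.5-fold higher number from compound 1 to compound 2 (0.19 log units; that floor lies within the scatter), and its size is set by the limit of > 166000 nM in this assay, at which 1 of the 3 values shown sits. Compound 4 `OC[C@H]1O[C@@H](n2cnc3c(NCc4ccccc4OC(F)F)ncnc32)[C@H](O)[C@@H]1O` differs from compound 1 by 2-(difluoromethoxy)phenyl in place of 2,4-dichlorophenyl on a saturated chain carbon bound to a nitrogen on an aromatic ring. That measured step also removed the 2,4-dichlorophenyl and did not bring a lower number, so a step of a 1.2-fold higher number from compound 1 to compound 4 (0.09 log units; within the scatter) is expected, toward a higher number or none beyond the scatter. Compound 4 is estimated at 130000 nM, with an expected range from 60000 nM to 280000 nM.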

Compound 4, half-maximal inhibitory concentration: > 166000 nM
Compound 4: no number, only a limit; the forecaster's own chance of this, stated with the estimate: 35%; at least 1.2-fold (0.10 log units) between middle value and limit.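

The step shows an at least 1.5-fold higher number from compound 1 to compound 4 (0.19 log units; that floor lies within the scatter), so a second group in place of 2,4-dichlorophenyl, on a saturated chain carbon bound to a nitrogen on an aromatic ring, brings no lower number in this assay. The step from compound 2 to compound 4 cannot be read, and the true size of the step to compound 4 stays unknown because it is set by a limit: the limit of > 166000 nM in this assay, at which 2 of the 4 values shown sit.

The compounds shown leave open whether any group at this place moves the number beyond the scatter of compound 1. A phenyl carrying an amine or a carboxylic acid in place of 2,4-dichlorophenyl might answer that.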